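Swapping the chloro for pyrrolidine on the pyridyl arm

A few compounds are considered here, and "the series" means these few. Any claim that something is new, unique, unknown or untested is made for them only; others in the source may bear on it.

Measured compounds:
compound 1 `O=C(O)Cc1sc(C(c2ccc(F)cc2)c2ccc(F)cc2)nc1-c1cc(F)cc(F)c1`, 35 nM
compound 2 `O=C(O)Cc1sc(C(c2ccc(F)cc2)c2ccc(F)cc2)nc1-c1ccnc(F)c1`, 0.48 nM
compound 3 `O=C(O)Cc1sc(C(c2ccc(F)cc2)c2ccc(F)cc2)nc1-c1ccnc(Cl)c1`, 3.1 nM

All three share one core and differ only in the aryl group on the thiazole carbon. In an in vitro assay on HEK385-7 cells for displacement of a labelled ligand from prostaglandin D2 receptor 2 (Homo sapiens) (on this read-out higher numbers stand for weaker inhibition and lower numbers for stronger inhibition), compound 3 stands second of the three: it sits an 11-fold lower number from compound 1 to compound 3 (1.05 log units; beyond the scatter) and a 6.5-fold higher number from compound 2 to compound 3 (0.81 log units; beyond the scatter). The unmeasured compound 4 `O=C(O)Cc1sc(C(c2ccc(F)cc2)c2ccc(F)cc2)nc1-c1ccnc(N2CCCC2)c1` keeps the 2-substituted pyridin-4-yl arm of compound 3 but changes the small substituent: pyrrolidin-1-yl in place of chloro on an aromatic carbon.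

For the measured compounds named here, no measured step replaces a halogen with a pyrrolidin-1-yl, so the bearing steps are indirect. The step of a 6.5-fold higher number from compound 2 to compound 3 (0.81 log units; beyond the scatter) shows that enlarging the group next to the ring nitrogen from fluoro to chloro already weakened inhibition, while a 73-fold lower number from compound 1 to compound 2 (1.86 log units; beyond the scatter) and an 11-fold lower number from compound 1 to compound 3 (1.05 log units; beyond the scatter) show the pyridin-4-yl arm itself is strongly favoured over 3,5-difluorophenyl. Pyrrolidin-1-yl is larger again than chloro, so a further modest weakening is expected, though the added acceptor leaves the direction uncertain. Compound 4 is therefore estimated at 8 nM, within 1.5 nM to 45 nM, a step of a 2.6-fold higher number from compound 3 to compound 4 (0.41 log units; beyond the scatter).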

Compound 4, half-maximal inhibitory concentration: 230 nM
For compound 4 the middle estimate is 29-fold (1.46 log units) below the measured one, outside the stated range (above it).
By their numbers in this assay, from the lowest: compound 2; then compound 3; then compound 1; then compound 4.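

At the place next to the ring nitrogen, pyrrolidin-1-yl costs far more than the halogen swap had shown, in this assay (a 74-fold higher number from compound 3 to compound 4 (1.87 log units; beyond the scatter)) and (a 480-fold higher number from compound 2 to compound 4 (2.68 log units; beyond the scatter)), against (a 6.5-fold higher number from compound 2 to compound 3 (0.81 log units; beyond the scatter)) for chloro in place of fluoro. The advantage of the pyridyl arm also depends on what this carbon carries: with pyrrolidin-1-yl, the arm falls behind 3,5-difluorophenyl (a 6.6-fold higher number from compound 1 to compound 4 (0.82 log units; beyond the scatter)), reversing the order seen with both halogens. Nothing available here accounts for this loss. The compounds shown leave open whether the attached nitrogen or the five-membered ring matters more, a question that a dimethylamino or a cyclopentyl group on the same carbon would address. They also leave open how a methoxy group or a plain hydrogen there would compare with fluoro and chloro.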